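From hexyloxy to methoxy on compound 3

The source may hold more compounds than are shown below. What is called first, only, known or untested is meant among the compounds shown, and "the series" means these compounds.

Compound 1 `Cn1c2cnc1OCCCCCCCCCCCOc1ccccc1-2`: 47000 nM
Compound 2 `C=CCCCCOc1cc2ccccc2cc1-c1cnc(OCCC=C)n1C`: 25000 nM
Compound 3 `CCCCCCOc1ncc(-c2ccccc2OC)n1C`: 43000 nM

All three compounds were measured in a functional assay on SK-MEL-28 cells (Homo sapiens) for inhibition, read by colorimetric assay and MTT assay, with a stated time of 72 h; on this read-out higher numbers stand for weaker inhibition and lower numbers for stronger inhibition. Compound 3, at 43000 nM, stands within the scatter of both others, so the numbers set no order among the three. The next compound to be measured in this assay is compound 4 `COc1ccccc1-c1cnc(OC)n1C`. It differs from compound 3 in one place: hydrogen in place of pentyl on a saturated chain carbon bound to an oxygen on an aromatic ring. In words, hydrogen takes the place of pentyl on a saturated chain carbon bound to an oxygen on an aromatic ring, which turns hexyloxy into methoxy.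

Among the compounds with values here, no measured pair differs in only one place, so the size of this step cannot be read directly from the data. Within the data shown here, the only guide is the narrow spread of the values. Compound 1 gives 47000 nM and compound 2 gives 25000 nM, although their structures differ clearly from that of compound 3. On that basis, no step beyond the scatter is expected, with a slight lean towards a higher number. The estimated step is a 1.3-fold higher number from compound 3 to compound 4 (0.11 log units; within the scatter). For compound 4 the estimate is 55000 nM, with an expected range of 25000 nM to 130000 nM.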

Compound 4, half-maximal inhibitory concentration: > 100000 nM
Compound 4 gave a limit, no number; the forecaster's own chance of this, stated with the estimate: 20%; at least 1.8-fold (0.25 log units) between middle value and limit.
By their numbers in this assay, from the lowest: compounds 2, 3 and 1 (each within the scatter of the next). At a limit, above all of these: compound 4.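

Cutting hexyloxy back to methoxy is the one change here that moves the read-out beyond the scatter: hydrogen in place of pentyl on a saturated chain carbon bound to an oxygen on an aromatic ring gives an at least 2.3-fold higher number from compound 3 to compound 4 (0.36 log units; beyond the scatter) in this assay. Compound 4 gives a limit and not a number in this assay (> 100000 nM), so this step has a lower bound but no measured size. The earlier compounds shown here, whose numbers all lie within the scatter of one another, gave no sign that this position mattered, whereas this pair shows that the five carbons of the pentyl part count for the inhibition seen with this core, a reading that rests on a single limit: the limit of > 100000 nM in this assay, at which 1 of the 4 values shown sits.

The compounds shown leave open how the read-out runs between methoxy and hexyloxy, for instance with a propoxy chain, and whether a chain longer than hexyloxy would give a lower number. They also leave open whether a chain of the same length ending in an amine or a carboxylic acid would hold the number of compound 3.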